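Adding a 4-chlorobenzyl group on the indole-type nitrogen of compound 1

The source may hold more compounds than are shown below. What is called first, only, known or untested is meant among the compounds shown, and "the series" means these compounds.

The measured compounds and their values:
Compound 1, `Clc1ccc(-c2nc(-c3c[nH]c4ccccc34)co2)cc1`, 410000 nM
Compound 2, `c1ccc2c(-c3cocn3)c[nH]c2c1`, 103000 nM
Compound 3, `c1ccc2c(-c3coc(C4CCNCC4)n3)c[nH]c2c1`, 295000 nM

In a functional assay on MCF7 cells (Homo sapiens) for cytotoxicity, read by MTT assay, with a stated time of 48 h (on this read-out higher numbers stand for weaker inhibition and lower numbers for stronger inhibition), compound 1 gives the highest of the three numbers. Its nearest neighbour is compound 3, reached by the step of a 1.4-fold lower number from compound 1 to compound 3 (0.14 log units; within the scatter), which stays within the scatter. Its furthest neighbour is compound 2, reached by a 4.0-fold lower number from compound 1 to compound 2 (0.60 log units; beyond the scatter), a modest change beyond the scatter. Between the two smaller compounds, a 2.9-fold higher number from compound 2 to compound 3 (0.46 log units; beyond the scatter).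

Compound 4, `Clc1ccc(Cn2cc(-c3coc(-c4ccc(Cl)cc4)n3)c3ccccc32)cc1`, differs from compound 1 in one place: 4-chlorobenzyl in place of hydrogen on an aromatic nitrogen. Among the measured compounds shown here, none of the measured steps touches this nitrogen; all three concern the group on the aromatic carbon of the five-membered ring bearing the oxazole-type substituent. The data therefore give no direct guide for the change from compound 1 to compound 4, and the measured steps at the other position were at most modest in size.

With the core kept and a group of this size added where nothing has been varied before, the expected outcome for compound 4 is a number close to that of compound 1, and the estimated step is a 1.6-fold lower number from compound 1 to compound 4 (0.21 log units; within the scatter). The estimate for compound 4 is 250000 nM, with a range from 60000 nM to 1000000 nM.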

Compound 4, half-maximal inhibitory concentration: 14100 nM
Compound 4: middle estimate off by 18-fold (1.25 log units), on the high side; the whole stated range lies above it.
By their numbers in this assay, from the lowest: compound 4; then compound 2; then compounds 3 and 1 (each within the scatter of the next).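

Among the compounds shown here, the nitrogen of the five-membered ring, which none of the earlier compounds varied, turns out to respond strongly in this assay: the step shows a 29-fold lower number from compound 1 to compound 4 (1.46 log units; beyond the scatter). For the compounds shown here, this is the only step so far printed as large, whereas the changes on the aromatic carbon stayed modest or within the scatter, so the larger shift in the number comes from this nitrogen. Putting 4-chlorobenzyl in place of hydrogen here moves the number towards stronger inhibition, which also shows that the hydrogen on this nitrogen is not required for activity on this read-out, although nothing available explains the size of the step.

As far as these compounds go, it remains open whether this shift belongs to 4-chlorobenzyl itself or would also follow from a plain methyl, an unsubstituted benzyl or a longer chain ending in an amine on the same nitrogen. From the compounds shown here alone, it is equally open whether 4-chlorobenzyl on this nitrogen would give a step of similar size on compound 2 or compound 3, where hydrogen or piperidin-4-yl stands in place of 4-chlorophenyl.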